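This account rests on a few compounds, and the source may have more. Where it says the series, first, only, none or still open, it means among the compounds named here.

Compound 1 `COc1cccc(/C=N/c2c(C)n(C)n(-c3ccccc3)c2=O)c1` was examined in a functional assay on HCT-116 cells (Homo sapiens) for cytotoxicity, read by MTT assay, with a stated time of 72 h (a lower number here means a stronger inhibitor, a higher number a weaker inhibitor), where compound 1 gives 933000000 nM. Among the two numbers measured so far this is the highest one. Within the data shown here, the only other measured compound, compound 2 `COc1cccc(/C=N/c2c(C)n(C)n(-c3ccccc3)c2=O)c1O`, carries a hydroxy in place of a hydrogen on an aromatic carbon, and in this assay compound 2 gives 89100000 nM; that change produced a 10-fold lower number from compound 1 to compound 2 (1.02 log units; beyond the scatter). Compound 3 `Cc1c(/N=C/c2ccc(Cl)cc2Cl)c(=O)n(-c2ccccc2)n1C` differs from compound 1 in a different way: 2,4-dichlorophenyl in place of 3-methoxyphenyl on a carbon with a double bond to nitrogen. Among the measured compounds shown here, no measured step bears on this change, since the single known step concerns an added hydroxy and not an exchange of one aryl group for another. With nothing pointing in either direction, no step beyond the usual scatter is expected. Compound 3 is therefore estimated to give 600000000 nM in this assay, with a range from 100000000 nM to 3000000000 nM. The expected step is a 1.6-fold lower number from compound 1 to compound 3 (0.19 log units; within the scatter).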

Compound 3, half-maximal inhibitory concentration: 269000000 nM
For compound 3 the middle estimate is 2.2-fold (0.35 log units) above the measured one; measured number inside the range.
By their numbers in this assay, from the lowest: compound 2; then compound 3; then compound 1.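

Exchanging the whole aryl group on the carbon with a double bond to nitrogen also moves the number in this assay: putting 2,4-dichlorophenyl in place of 3-methoxyphenyl gives a 3.5-fold lower number from compound 1 to compound 3 (0.54 log units; beyond the scatter). The earlier step only added a hydroxy to the ring and kept the methoxy, whereas compound 3 has no methoxy and no oxygen on this ring, so a lower number than that of compound 1 does not require either. No measurement at hand explains this step.

The exchange removes the methoxy and adds two chlorines in a single step, so the compounds shown cannot separate the share of each change. On these data alone, it also remains open how this number would respond to a ring with a single chlorine, an amine or a carboxylic acid.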